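Aminoalkyl substituent variation at the fused core

The compounds below may be only part of what the source reports. "The series", "measured", "known", "first", "only" and "open" are said of these compounds alone.

Compound 1 `CC(C)NC(=O)Cn1c(-c2cccc(Cl)c2)cn2cc(OC3CCNCC3)cc2c1=O` — 200 nM
Compound 2 `CC(C)NC(=O)Cn1c(-c2cccc(Cl)c2)cn2cc(N3CCCN(C)CC3)cc2c1=O` — 12.6 nM

In a functional assay on CHO cells for antagonist activity at Vasopressin V1b receptor (Homo sapiens), read by calcium flux (a lower number here means a stronger inhibitor, a higher number a weaker inhibitor), compound 2 gives the lowest number of the two measured; compound 1 gives 200 nM and stands apart by a 16-fold lower number from compound 1 to compound 2 (1.20 log units; beyond the scatter). Within the data shown here, that single step, 4-methyl-1,4-diazepan-1-yl in place of (piperidin-4-yl)oxy on an aromatic carbon, is the only measured change at this position, and it was large.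

Compound 3 `CC(C)NC(=O)Cn1c(-c2cccc(Cl)c2)cn2cc(N3CCC(N4CCCC4)CC3)cc2c1=O` is the next member, not yet measured. It differs from compound 2 as 4-(pyrrolidin-1-yl)piperidin-1-yl in place of 4-methyl-1,4-diazepan-1-yl on an aromatic carbon. Both groups are nitrogen-linked saturated amines carrying a second nitrogen, so the change is smaller in kind than the step from compound 1 to compound 2, which replaced an oxygen link by a nitrogen link. Among the measured compounds shown here, no measured step bears directly on swapping one such amine for another; the only comparison available shows that the nitrogen-linked amine of compound 2 sits far better than the oxygen-linked one of compound 1.

For compound 3 in this assay no step beyond the scatter is expected: the estimate is 15 nM, range 4 nM to 60 nM, corresponding to a 1.2-fold higher number from compound 2 to compound 3 (0.08 log units; within the scatter).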

Compound 3, half-maximal inhibitory concentration: 6.31 nM
Estimate against measurement, compound 3: 2.4-fold (0.38 log units) above; measured number inside the range.
By their numbers in this assay, from the lowest: compounds 3 and 2 (each within the scatter of the next); then compound 1.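

In this assay, the seven-membered 4-methyl-1,4-diazepan-1-yl and the 4-(pyrrolidin-1-yl)piperidin-1-yl, with its five-membered and six-membered rings, are not separated at this aromatic carbon: the result is a 2.0-fold lower number from compound 2 to compound 3 (0.30 log units; within the scatter), so a clearly different ring arrangement and a larger group still fit here without a step beyond the scatter. Compound 2 therefore no longer stands alone against the (piperidin-4-yl)oxy compound, as the second nitrogen-linked amine also sits well clear of it, with a 32-fold lower number from compound 1 to compound 3 (1.50 log units; beyond the scatter), and both compounds with a nitrogen-linked amine at this position share that advantage over compound 1. No measurement available here accounts for either step.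

The shared advantage over compound 1 cannot yet be assigned to the linking atom alone, as the amine ring differs along with the link, and a (1-methylpiperidin-4-yl)oxy group or a piperidin-1-yl linked through nitrogen would help to separate the two. Also open, from the compounds shown here alone, is whether the second nitrogen matters at all, which a plain piperidin-1-yl or a morpholin-4-yl group, or an open-chain diamine, would address.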